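The compounds below may be only part of what the source reports. "The series", "measured", "known", "first", "only" and "open" are said of these compounds alone.

Measured so far:
compound 1 `COc1cc(OC)c(OC)cc1/C=C/COC(=O)/C=C/c1ccccc1Cl` — 100%
compound 2 `COc1cc(OC)c(OC)cc1/C=C/COC(=O)/C=C/c1ccc(F)cc1` — 100%

In a functional assay on the whole organism (strain Kunming) with Mus musculus as the target, with a stated time of 0.5 h, at a dose of 300 mg/kg by the intraperitoneal route (on this read-out lower numbers stand for a stronger effect and higher numbers for a weaker effect at the one dose given), compound 1 gives 100%. In this assay compound 2 gives 100%. Among the measured compounds shown here, the one measured step, no change at the digits printed from compound 1 to compound 2 (within the scatter), puts 4-fluorophenyl in place of 2-chlorophenyl on a double-bonded chain carbon bound to a double-bonded chain carbon. Compound 2 therefore stands level with compound 1 at the digits shown; no ordering between the two is supported.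

Compound 3 `COc1cc(OC)c(OC)cc1/C=C/COC(=O)/C=C/c1ccc(Cl)cc1` is not yet measured. Relative to compound 2 the change is chloro in place of fluoro on an aromatic carbon; cut one bond further out it reads 4-fluorophenyl to 4-chlorophenyl. For the measured compounds named here, no measured step exchanges one halogen for another at the same aromatic carbon, so the only bearing comes from the step from compound 1 to compound 2, which swapped the whole halogenated ring and left the read-out unchanged within the scatter.

On that basis no step beyond the scatter is expected, and the estimated step of no change at the digits printed from compound 2 to compound 3 (within the scatter) is set accordingly. For compound 3 the expected value in this assay is 100%, with a range from 85% to 100%.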

Compound 3, a percentage reported as activity, at one dose (the size of the read-out at that dose, not a potency): 100%
Estimate against measurement, compound 3: no gap at the digits printed; the range from low to high includes it.
By their numbers in this assay, from the lowest: compounds 1, 2 and 3 (each within the scatter of the next).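

In this assay, among the compounds shown here, the exchange of fluoro for chloro on this aromatic carbon, para to a large group, gives no change at the digits printed from compound 2 to compound 3 (within the scatter), the first reading of a halogen exchange at a single site, whereas the earlier step changed the halogen and its place on the ring together. With chlorine kept as the halogen, 4-chlorophenyl in place of 2-chlorophenyl gives no change at the digits printed from compound 1 to compound 3 (within the scatter), so the earlier ring swap now divides into two separate steps, and neither the halogen exchange nor the shift of chlorine separates these compounds at this single dose. Nothing available explains this outcome or gives a measured property of these groups.

The compounds shown leave open whether an unsubstituted phenyl ring, or a ring carrying a methoxy group, a nitrile or an amine at this carbon, would depart from the read-out shared by these three halogenated compounds. They also leave open whether an amide in place of the ester, or a longer chain between the ester and the ring, would separate from this series.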